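Acetyl for pyridin-2-yl on the piperazine of compound 3

The compounds below may be only part of what the source reports. "The series", "measured", "known", "first", "only" and "open" are said of these compounds alone.

The series is followed in an assay on isolated protein for binding affinity to Polycomb protein EED (Homo sapiens), read by TR-FRET and LanthaScreen, with a stated time of 1 h; a higher number here means a weaker inhibitor, a lower number a stronger inhibitor. Compound 1, `CN(C)[C@H]1CN(C2CCc3cccc(F)c32)C[C@@H]1C1CCN(c2ccc(C(N)=O)cn2)CC1`, gives 0.45 nM in this assay. Compound 2, `CN(C)[C@H]1CN(Cc2c(F)cccc2Br)C[C@@H]1C1CCCCC1`, is far weaker in this assay, at 230 nM. Compound 3, `Cc1cccc(F)c1CN1C[C@H](c2ccc(N3CCN(c4ccccn4)CC3)cc2)[C@@H](N(C)C)C1`, gives 2.1 nM in this assay, the second highest of the three numbers: its number is above that of compound 1 by a margin beyond the scatter, and far below that of compound 2, again beyond the scatter.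

Compound 4, `CC(=O)N1CCN(c2ccc([C@H]3CN(Cc4c(C)cccc4F)C[C@@H]3N(C)C)cc2)CC1`, has not yet been measured in this assay. It differs from compound 3 in one place: acetyl in place of pyridin-2-yl on an amine nitrogen in a ring

No pair among the measured compounds differs in a single place, so the size of this kind of step is not shown by the data. The change keeps the shared core of compound 3 intact and swaps only the group on the amine nitrogen in a ring. Compound 4 is therefore expected to stay in the low range, with a modest rise in the number, estimated as a 2.4-fold higher number from compound 3 to compound 4 (0.38 log units; beyond the scatter). On that basis compound 4 is expected to give about 5 nM in this assay, within a range of 1.5 nM to 20 nM.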

Compound 4, inhibition constant: 2.6 nM
Estimate against measurement, compound 4: 1.9-fold (0.28 log units) above; the range from low to high includes it.
By their numbers in this assay, from the lowest: compound 1; then compounds 3 and 4 (each within the scatter of the next); then compound 2.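

In this assay, within the data shown here, the exchange of pyridin-2-yl for acetyl on the amine nitrogen in a ring comes to a 1.2-fold higher number from compound 3 to compound 4 (0.09 log units; within the scatter) and is the first step that can be read in a single place. It shows that this position accepts a large reduction in the group it carries: six heavy atoms with an aromatic ring leave and three heavy atoms with no ring enter, yet compound 3 and compound 4 cannot be told apart in this measurement. No measured evidence bears on why the step is so small, so the result records the outcome and gives no explanation for it.

The compounds shown leave open whether the aromatic ring and the carbonyl can both be dispensed with, as a methyl group or a bare amine hydrogen on that nitrogen would test, and whether a carboxylic acid on a longer chain would be accepted there. They also leave open whether the same exchange would be as small on the core of compound 1.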